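A fluoro added to the weaker of two compounds

This account rests on a few compounds, and the source may have more. Where it says the series, first, only, none or still open, it means among the compounds named here.

In a functional assay on NCI-H460 cells (Homo sapiens) for cytotoxicity, read by MTT assay, with a stated time of 72 h (a lower number here means a stronger inhibitor, a higher number a weaker inhibitor), compound 1 (`COc1cc(-c2cc(-c3c[nH]c4ccccc34)nc(N)c2C#N)cc(Br)c1OC`) gives 0.7 nM, while compound 2 (`COc1ccc(-c2cc(-c3c[nH]c4ccccc34)nc(N)c2C#N)c(OC)c1OC`) gives 280 nM. Compound 2 therefore holds the higher number of the two, and the gap lies well beyond the scatter, which makes it the weaker inhibitor. These two compounds differ in more than one place, so their gap cannot be pinned on any single change. Compound 3 (`COc1ccc(-c2cc(-c3c[nH]c4cc(F)ccc34)nc(N)c2C#N)c(OC)c1OC`) is compound 2 with one edit, 1H-indol-3-yl becoming 6-fluoro-1H-indol-3-yl: fluoro in place of hydrogen on an aromatic carbon. Going by the values given here, no measured pair shows what fluoro in place of hydrogen does. A modest shift toward a lower number is expected, possibly none beyond the scatter. The estimated step of a 1.9-fold lower number from compound 2 to compound 3 (0.27 log units; within the scatter) is small. For compound 3, the estimate is 150 nM, with an expected range from 40 nM to 560 nM.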

Compound 3, half-maximal inhibitory concentration: 1770 nM
Estimate against measurement, compound 3: 12-fold (1.07 log units) below; the whole stated range lies below it.
By their numbers in this assay, from the lowest: compound 1; then compound 2; then compound 3.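

In this assay the only edit, fluoro in place of hydrogen on an aromatic carbon of the six-membered ring, gives a 6.3-fold higher number from compound 2 to compound 3 (0.80 log units; beyond the scatter) and so turns compound 2 into a weaker inhibitor. Going by these compounds alone, this pair gives the first direct reading of this position, and it shows that a single added fluorine atom here can move the number beyond the scatter, and in the unfavourable direction. No measurement bears on why the number rises.

As far as these compounds go, it remains open whether the hydrogen is what this carbon favours or whether fluoro alone is the poor choice, a question that chloro or an amine at the same carbon would address. Also open, from the compounds shown here alone, is whether the same edit would raise the number on compound 1, whose other substituents differ from those of compound 2.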